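Swapping Methoxy for Chloro in a Cytotoxicity Series

A few compounds are considered here, and "the series" means these few. Any claim that something is new, unique, unknown or untested is made for them only; others in the source may bear on it.

Of the compounds shown here, three have been measured in an ADME assay on NIH3T3 cells (Mus musculus) for cytotoxicity, read by MTT assay, with a stated time of 24 h (a higher number here means a weaker inhibitor, a lower number a stronger inhibitor), a test of how much compound is needed to harm cultured mouse cells. Compound 1 `COc1ccccc1N1CCN(CC(=O)N2CCN(c3nnc(-c4ccccc4)c(-c4ccccc4)n3)CC2)CC1` gives 444000 nM. Compound 2 `O=C(CN1CCN(c2ccccc2Cl)CC1)N1CCN(c2nnc(-c3ccccc3)c(-c3ccccc3)n2)CC1` differs from it in one place, (chloro in place of methoxy on an aromatic carbon), and in this assay compound 2 gives 350000 nM. The step of a 1.3-fold lower number from compound 1 to compound 2 (0.10 log units; within the scatter) is small. Compound 3 `COc1ccccc1N1CCN(CC(=O)N2CCN(c3nnc(-c4ccc(Cl)cc4)c(-c4ccc(Cl)cc4)n3)CC2)CC1` is built on a different core; how its core differs from that of compound 1 is not broken down here. In this assay compound 3 gives 405000 nM. The numbers for compounds 1, 2 and 3 all lie within the usual scatter of one another, so no order among them can be read. Compound 4 `O=C(CN1CCN(c2ccccc2Cl)CC1)N1CCN(c2nnc(-c3ccc(Cl)cc3)c(-c3ccc(Cl)cc3)n2)CC1` has not yet been measured; it differs from compound 3 by chloro in place of methoxy on an aromatic carbon, the same change that separates compound 1 from compound 2. Because the earlier step of a 1.3-fold lower number from compound 1 to compound 2 (0.10 log units; within the scatter) stayed within the scatter, a similar step is expected for compound 4, a 1.3-fold lower number from compound 3 to compound 4 (0.10 log units; within the scatter). Compound 4 is therefore estimated to give 320000 nM in this assay, most likely between 160000 nM and 640000 nM.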

Compound 4, half-maximal inhibitory concentration: > 803000 nM
Compound 4: no number, only a limit; the forecaster's own chance of this, stated with the estimate: 15%; middle value at least 2.5-fold (0.39 log units) away from the limit.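

In this assay compound 4 gives only a limit of the assay, > 803000 nM, and not a number. Going from 2-methoxyphenyl to 2-chlorophenyl on this core gives an at least 1.9-fold higher number from compound 3 to compound 4 (0.29 log units; that floor lies within the scatter), so the true size of the step remains unknown and even its floor does not show a real change. The result neither shows that the change carries over from one core to the other nor shows that it behaves differently on each: the same change on two cores in this assay, a 1.3-fold lower number (0.10 log units; within the scatter) from compound 1 to compound 2 and an at least 1.9-fold higher number (0.29 log units; that floor lies within the scatter) from compound 3 to compound 4; the limit leaves it open whether they differ.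

The compounds shown hold only methoxy or chloro at this place on the aromatic ring, so it remains open how a fluoro, a methyl, an amine or a carboxylic acid there would read in this assay. From the compounds shown here alone, it also remains open whether a longer chain between the two parts of the molecule would shift the reading, and two cores are too few to set a rule for the series.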